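The source may report more compounds than this note shows. Statements on the series, on what has been measured and on what is new or still open speak of the compounds shown alone.

Going by the values given here, compound 2 `O=C(/C=C/c1ccccc1)Nc1nc2ccccc2s1` gives 646 umol/kg in a functional assay on the whole organism (Hindlimb, strain albino) with Mus musculus as the target, in the maximal electroshock model, with a stated time of 0.5 h; on this read-out lower numbers stand for an effect already at smaller amounts and higher numbers for an effect only at larger amounts of compound; the only other number in hand belongs to compound 1 `COc1ccc(/C=C/C(=O)Nc2nc3ccccc3s2)cc1`, which in this assay gives 435 umol/kg, and the two lie within the scatter of each other, as the step of a 1.5-fold higher number from compound 1 to compound 2 (0.17 log units; within the scatter) shows. Compound 3 `O=C(/C=C/c1ccccc1)Nc1nc2ccc(Cl)cc2s1` has not been measured. It differs from compound 2 by chloro in place of hydrogen on an aromatic carbon, the change sitting on the fused core rather than on the cinnamoyl-side ring. Among the compounds with values here, the single measured step, a 1.5-fold higher number from compound 1 to compound 2 (0.17 log units; within the scatter), concerns a substituent on that other ring and was itself within the scatter, so nothing in hand tests a chloro entering the core. Within the data shown here, with no step bearing on it, the expectation for compound 3 is no shift beyond the scatter, a step of a 1.2-fold lower number from compound 2 to compound 3 (0.07 log units; within the scatter) in this assay. Compound 3 is therefore estimated at 550 umol/kg, with a range from 250 umol/kg to 1200 umol/kg.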

Compound 3, dose for half-maximal effect: 425 umol/kg
Compound 3: middle estimate off by 1.3-fold (0.11 log units), on the high side, within the range that was stated.
By their numbers in this assay, from the lowest: compounds 3, 1 and 2 (each within the scatter of the next).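

The core now has its first tested change: chloro in place of hydrogen on an aromatic carbon of the fused system, with a 1.5-fold lower number from compound 2 to compound 3 (0.18 log units; within the scatter) in this assay. This position therefore takes one chlorine atom without a shift that can be told from the scatter, whereas the earlier step, a 1.5-fold higher number from compound 1 to compound 2 (0.17 log units; within the scatter), spoke only to the ring on the cinnamoyl side. Nothing available explains the size of this step.

Still open is whether a methoxy, an amine or a carboxylic acid on this same carbon of the core would move the number beyond the scatter, since chloro is the only group shown here. Also open, from the compounds shown here alone, is what chloro on the core and methoxy on the cinnamoyl-side ring would give together in one compound.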